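Swapping Propyl for Pyridin-2-yl on an Amide

The source may hold more compounds than are shown below. What is called first, only, known or untested is meant among the compounds shown, and "the series" means these compounds.

In a functional assay on the whole organism with Mus musculus as the target (on this read-out higher numbers stand for an effect only at larger amounts of compound and lower numbers for an effect already at smaller amounts), compound 1 (`COc1ccc(-c2nc3cccnc3n2CC(=O)N(C)C)cc1`) gives 39.5 mg/kg and compound 2 (`CCCNC(=O)Cn1c(-c2ccc(Cl)cc2)nc2cccnc21`) gives 37.5 mg/kg as its number, so these two values lie within the usual scatter of each other. Compound 3 (`O=C(Cn1c(-c2ccc(Cl)cc2)nc2cccnc21)Nc1ccccn1`) carries pyridin-2-yl in place of propyl on an amide-type nitrogen. Within the data shown here, no measured pair shows such a swap, so for this assay no step beyond the scatter is expected, and this remains a cautious guess (a 1.3-fold lower number from compound 2 to compound 3 (0.10 log units; within the scatter)). For compound 3 the estimated value is 30 mg/kg (range 10 mg/kg to 90 mg/kg).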

Compound 3, dose for half-maximal effect: 100 mg/kg
The estimate for compound 3 lay 3.3-fold (0.52 log units) below the measured number; the whole stated range lies below it.
By their numbers in this assay, from the lowest: compounds 2 and 1 (each within the scatter of the next); then compound 3.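

The amide nitrogen is not indifferent to what it carries: in this assay putting pyridin-2-yl in place of propyl gives a 2.7-fold higher number from compound 2 to compound 3 (0.43 log units; beyond the scatter) and so moves the effect to larger doses. Among these compounds, this modest step is the first one here beyond the scatter, though it rests on a single pair. Nothing at hand explains it.

From the compounds shown here alone, whether the ring itself or simply the larger group matters stays open. Phenyl or cyclohexyl on the same nitrogen, or a longer chain such as butyl, would help separate the two.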